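A Larger Group in Place of Chloro on Compound 2

The source may report more compounds than this note shows. Statements on the series, on what has been measured and on what is new or still open speak of the compounds shown alone.

Compound 2 `CC(C)Nc1sc(C(=O)c2ccc(Cl)s2)c(N)c1C#N` gives the lowest number in an assay for inhibition of Maternal embryonic leucine zipper kinase (Homo sapiens), read by ADP-Glo, with a stated time of 0.5 h (a higher number here means a weaker inhibitor, a lower number a stronger inhibitor), at 192 nM. Compound 3 `CC(C)Nc1sc(C(=O)c2cc(Cl)cs2)c(N)c1C#N` gives 575 nM, and the step of a 3.0-fold higher number from compound 2 to compound 3 (0.48 log units; beyond the scatter) lies beyond the scatter. Compound 1 `CC(C)Nc1sc(C(=O)c2ccncc2)c(N)c1C#N` gives > 5000 nM, which is a limit of this assay rather than a number. The steps of an at least 26-fold lower number from compound 1 to compound 2 (1.41 log units; beyond the scatter) and an at least 8.6-fold lower number from compound 1 to compound 3 (0.93 log units; beyond the scatter) show the chlorinated five-membered ring far ahead of pyridin-4-yl.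

Compound 4 `CC(C)Nc1sc(C(=O)c2ccc(-c3ccc(O)cc3)s2)c(N)c1C#N` carries 4-hydroxyphenyl in place of chloro on an aromatic carbon. Going by the values given here, no measured step touches this position with a group of this kind, so the measured steps give only the range the series has covered. A modest weakening is estimated, a 2.6-fold higher number from compound 2 to compound 4 (0.42 log units; beyond the scatter), so compound 4 is expected near 500 nM, between 100 nM and 3000 nM.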

Compound 4, half-maximal inhibitory concentration: 241 nM
Compound 4: the middle estimate sits 2.1-fold (0.32 log units) above what was measured, and the stated range covers the measured number.
By their numbers in this assay, from the lowest: compounds 2 and 4 (each within the scatter of the next); then compound 3. At a limit, above all of these: compound 1.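

In this assay, this position on an aromatic carbon next to the ring sulfur accepts a much larger group than chloro: 4-hydroxyphenyl in place of chloro gives a 1.3-fold higher number from compound 2 to compound 4 (0.10 log units; within the scatter) and leaves compound 2 and compound 4 indistinguishable. The earlier compounds shown here varied where chloro sat or replaced the whole ring, so they could not show this tolerance for an added six-membered aromatic ring.

The compounds shown leave open how a plain phenyl, an amine or a carboxylic acid would fare at this position. Nothing given here bears on why compound 2 and compound 4 read alike.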